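Peptide aldehyde series: side-chain swap at the aldehyde-bearing carbon

The source may report more compounds than this note shows. Statements on the series, on what has been measured and on what is new or still open speak of the compounds shown alone.

Among the measured compounds shown here, compound 1 `CC(=O)N[C@@H](CO)C(=O)N[C@@H](C)C(=O)N[C@H](C(=O)N[C@@H](CC(C)C)C(=O)N[C@H](C=O)CCC(=O)N(C)C)C(C)C` holds the lower of the two numbers so far in an assay for inhibition of chymotrypsin-like protease CTRL-1 variant R188I (Homo sapiens), read by HPLC, with stated times of 20 min and 60 min; a higher number here means a weaker inhibitor, a lower number a stronger inhibitor; compound 1 gives 37000 nM. Compound 2 `CCOC(=O)/C=C/[C@H](CCC(=O)N(C)C)NC(=O)[C@H](CC(C)C)NC(=O)[C@@H](NC(=O)[C@H](C)NC(=O)[C@H](CO)NC(C)=O)C(C)C` gives 330000 nM in this assay. For the measured compounds named here, the only single-point step in hand is an 8.9-fold higher number from compound 1 to compound 2 (0.95 log units; beyond the scatter), a change at the formyl end of the chain. Compound 3 `CCOC(=O)/C=C/CC[C@H](CCC(=O)N(C)C)NC(=O)[C@H](CC(C)C)NC(=O)[C@@H](NC(=O)[C@H](C)NC(=O)[C@H](CO)NC(C)=O)C(C)C` is reported in this assay as "not active" (no number reported), with no number. Compound 4 `CC(=O)N[C@@H](CO)C(=O)N[C@@H](C)C(=O)N[C@H](C(=O)N[C@@H](CC(C)C)C(=O)N[C@H](C=O)CC(C)C)C(C)C` differs from compound 1 elsewhere: isopropyl in place of (dimethylcarbamoyl)methyl on a saturated chain carbon, two bonds along the chain from an amide-type nitrogen and a carbonyl carbon. Going by the values given here, no measured step touches this side chain, so nothing speaks for a direction, and a step within the scatter is as plausible as one beyond it. The expected step is a 1.1-fold higher number from compound 1 to compound 4 (0.03 log units; within the scatter). Compound 4 is therefore estimated at 40000 nM, in the range 8000 nM to 200000 nM.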

Compound 4, half-maximal inhibitory concentration: 3000000 nM
For compound 4 the middle estimate is 75-fold (1.88 log units) below the measured one; measured number outside the range, above it.
By their numbers in this assay, from the lowest: compound 1; then compound 2; then compound 4.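

Among the compounds shown here, this side chain is the first position outside the formyl end with a measured step: in this assay, isopropyl in place of (dimethylcarbamoyl)methyl gives an 81-fold higher number from compound 1 to compound 4 (1.91 log units; beyond the scatter), beyond the scatter, so the position is far from indifferent to this change. Compound 1 keeps the lowest number of the three measured compounds. No measured data explain the loss. The amide carbonyl and the dimethylamino part leave together, so their separate contributions cannot be told apart. On these data alone, a primary amide, a carboxylic acid or a longer chain carrying the dimethylamide remains open here.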